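This account rests on a few compounds, and the source may have more. Where it says the series, first, only, none or still open, it means among the compounds named here.

In a functional assay, with a stated time of 60 min, in the absence of a further agent (a higher number here means a weaker inhibitor, a lower number a stronger inhibitor), compound 1 `COc1cc2c(cc1O)CCC(C)(CC(N)=O)O2` gives 10500 nM and compound 2 `COc1cc2c(cc1O)CCC(C)(CCNC(C)=O)O2` gives 14300 nM. For the measured compounds named here, compound 2 therefore stands within the scatter of the only other measured number. Going by the values given here, the one measured step, a 1.4-fold higher number from compound 1 to compound 2 (0.13 log units; within the scatter), puts acetamidomethyl in place of carbamoyl and does not exceed the scatter. Compound 3 `COc1cc2c(cc1O)CCC(C)(CC(N)C(=O)O)O2` carries amino(carboxy)methyl in place of acetamidomethyl on a saturated chain carbon bound to a saturated ring carbon. Among the compounds with values here, the measured step is the only one that bears on this change, as it falls at the same place, but no measured compound carries the entering group. The expectation in this assay is thus for no step beyond the scatter, held with wide uncertainty. The expected step is a 1.0-fold higher number from compound 2 to compound 3 (0.02 log units; within the scatter). For compound 3 the estimated value is 15000 nM, with an expected range from 5000 nM to 50000 nM.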

Compound 3, half-maximal inhibitory concentration: 14100 nM
Compound 3: middle estimate off by 1.1-fold (0.03 log units), on the high side, and the stated range covers the measured number.
By their numbers in this assay, from the lowest: compounds 1, 3 and 2 (each within the scatter of the next).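

In this assay, the place on a saturated chain carbon bound to a saturated ring carbon now holds a group that is not an amide, and the number does not move beyond the scatter: the change gives a 1.0-fold lower number from compound 2 to compound 3 (0.01 log units; within the scatter), and measured against carbamoyl it gives a 1.3-fold higher number from compound 1 to compound 3 (0.13 log units; within the scatter). Amino(carboxy)methyl carries both an amine and a carboxylic acid, with more hydrogen-bond donors and acceptors than acetamidomethyl at the same heavy-atom count, yet the three compounds cannot be told apart here. No measurement at hand accounts for this result.

The compounds shown leave open whether an amine alone, a carboxylic acid alone or a longer chain at this place would give a step beyond the scatter. From the compounds shown here alone, all three share the rest of the core, so what changes there would do also remains open.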